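From Nitro to Fluoro: One Change, One Expected Value

The source may report more compounds than this note shows. Statements on the series, on what has been measured and on what is new or still open speak of the compounds shown alone.

Compound 1 `COc1cc(NC(=O)Nc2ccccc2)cc(OC)c1OC` opens the set, but in a functional assay on ONS-76 cells (Homo sapiens) for cytotoxicity, read by MTT assay, with a stated time of 72 h (on this read-out higher numbers stand for weaker inhibition and lower numbers for stronger inhibition), compound 1 gives "not determined" (no result reported), so no result was reported for it. Among the compounds with values here, compound 2 `COc1cc(NC(=O)Nc2ccc([N+](=O)[O-])cc2)cc(OC)c1OC` carries the only number: in this assay compound 2 gives 35000 nM, which places it on the weak side of this read-out, and with no second number there is no ordering to draw. Compound 3 `COc1cc(NC(=O)Nc2ccc(F)cc2)cc(OC)c1OC` is the next compound and has not yet been measured. It differs from compound 2 in one place (fluoro in place of nitro on an aromatic carbon), fluoro in place of nitro on an aromatic carbon. Within the data shown here, no step between measured compounds exists to calibrate such a change, so the expectation rests on compound 2 alone. The author expects the step of a 1.4-fold higher number from compound 2 to compound 3 (0.15 log units; within the scatter) to be small, within the scatter or slightly toward weaker inhibition, because compound 2 at 35000 nM already sits far from strong activity and little room remains. Compound 3 is therefore estimated at 50000 nM, with a range from 15000 nM to 160000 nM, and a real chance that this assay returns only a limit.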

Compound 3, half-maximal inhibitory concentration: 63300 nM
Compound 3: middle estimate off by 1.3-fold (0.10 log units), on the low side; measured number inside the range.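

In this assay, within the data shown here, the exchange at this position, on an aromatic carbon para to a large group, gives a 1.8-fold higher number from compound 2 to compound 3 (0.26 log units; within the scatter) and so provides the first step that can be read in this set. Nitro, with 3 heavy atoms and 2 hydrogen-bond acceptors, leaves, and fluoro, with 1 heavy atom and 0 hydrogen-bond acceptors, enters, yet this replacement does not separate compound 2 from compound 3 on this read-out, and the single pair shows that this position accepts the two groups without a difference that can be distinguished from ordinary repeat variation. No independent measurement is available that would account for this outcome.

Steps involving compound 1 cannot be read, so the two substituted compounds cannot be set against the core of compound 1 with only a hydrogen at this position. On these data alone, it remains open whether an amine, a carboxylic acid or a longer alkyl chain at this same position would give a step beyond the scatter, or whether the number would stay where compound 2 and compound 3 lie.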